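Estimating an Indolylmethyl Swap on a Shared Core

The source may hold more compounds than are shown below. What is called first, only, known or untested is meant among the compounds shown, and "the series" means these compounds.

Of the compounds shown here, three with a shared core have been tested in a functional assay on K562 cells (Homo sapiens) for inhibition, read by trypan blue exclusion, with a stated time of 72 h; a lower number here means a stronger inhibitor, a higher number a weaker inhibitor. In this assay compound 1 (`Cn1c(=O)c(S(=O)(=O)c2ccc(F)cc2F)cc2cnc(Nc3ccc4[nH]ncc4c3)nc21`) gives 50000 nM, compound 2 (`Cn1ccc2cc(Nc3ncc4cc(S(=O)(=O)c5ccc(F)cc5F)c(=O)n(C)c4n3)ccc21`) gives 750 nM, and compound 3 (`Cn1c(=O)c(S(=O)(=O)c2ccc(F)cc2F)cc2cnc(Nc3cnc4[nH]ccc4c3)nc21`) gives 750 nM. Compound 3 therefore stands level with compound 2, and both numbers sit far under that of compound 1. Changing only the group carried on a nitrogen on an aromatic ring produced a 67-fold lower number from compound 1 to compound 2 (1.82 log units; beyond the scatter) and a 67-fold lower number from compound 1 to compound 3 (1.82 log units; beyond the scatter), while the remaining pair showed no change at the digits printed from compound 2 to compound 3 (within the scatter).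

Compound 4 (`Cn1c(=O)c(S(=O)(=O)c2ccc(F)cc2F)cc2cnc(NCc3ccc4[nH]ccc4c3)nc21`) is made from compound 3 by one change: a group of 10 heavy atoms (9 carbon, 1 nitrogen; one five-membered aromatic ring with 1 hetero atom, one six-membered aromatic ring of carbon only) in place of a group of 9 heavy atoms (7 carbon, 2 nitrogen; one five-membered aromatic ring with 1 hetero atom, one six-membered aromatic ring with 1 hetero atom), on a nitrogen on an aromatic ring. The entering group is (1H-indol-5-yl)methyl. Among the measured compounds shown here, none of the measured steps introduces this group, so the evidence is indirect. The step to compound 3 at a 67-fold lower number from compound 1 to compound 3 (1.82 log units; beyond the scatter) shows that the group at this place can move the number a great deal, so a real step is expected here too. The only departure seen so far from the level of compound 3 is upward, so the expected direction is towards a weaker inhibitor, with wide uncertainty. The expected step is a 4.0-fold higher number from compound 3 to compound 4 (0.60 log units; beyond the scatter). The estimated value for compound 4 is 3000 nM, with an expected range of 400 nM to 30000 nM.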

Compound 4, half-maximal inhibitory concentration: 75000 nM
Compound 4: middle estimate off by 25-fold (1.40 log units), on the low side; the measured number lies above the stated range.
By their numbers in this assay, from the lowest: compounds 2 and 3 (each within the scatter of the next); then compounds 1 and 4 (each within the scatter of the next).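

Replacing 1-methyl-1H-indol-5-yl with (1H-indol-5-yl)methyl on this nitrogen leaves the count at 10 heavy atoms (9 carbon, 1 nitrogen), yet in this assay it gives a 100-fold higher number from compound 2 to compound 4 (2.00 log units; beyond the scatter) and shows that the same atoms, arranged differently, can separate a stronger inhibitor from a much weaker one. The change from the other stronger compound is just as large, with a 100-fold higher number from compound 3 to compound 4 (2.00 log units; beyond the scatter), so at this place neither of the two stronger compounds has its level carried over to the (1H-indol-5-yl)methyl group. The new group also joins the weak end of the series, with a 1.5-fold higher number from compound 1 to compound 4 (0.18 log units; within the scatter) lying within the scatter, so compound 1 and compound 4 cannot be told apart here, and compound 1 shows that a group without the added methyl link can also give a number this high.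

Nothing shown here explains why these groups differ so sharply. The compounds shown leave open whether (1-methyl-1H-indol-5-yl)methyl or a longer chain such as 2-(1H-indol-5-yl)ethyl would stay at this weak level or return towards that of compound 2.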